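This account rests on a few compounds, and the source may have more. Where it says the series, first, only, none or still open, it means among the compounds named here.

In a functional assay on U-373MG ATCC cells for cytotoxicity against U373 MG (Homo sapiens), read by colorimetric assay and MTT assay (on this read-out lower numbers stand for stronger inhibition and higher numbers for weaker inhibition), three compounds built on one shared core have been measured. Compound 1 (`CCOC(=O)Cn1c(=O)c(-c2ccc(OC)cc2)cc2c(OC)cc(OC)cc21`) gives 10000 nM, compound 2 (`CCN(CC)C(=O)Cn1c(=O)c(-c2ccc(OC)cc2)cc2c(OC)cc(OC)cc21`) gives 10000 nM, and compound 3 (`COc1ccc(-c2cc3c(OC)cc(OC)cc3n(CC#N)c2=O)cc1`) gives 10000 nM. Compound 3 thus stands level with the other two at the digits reported.

Compound 4 (`COc1ccc(-c2cc3c(OC)cc(OC)cc3n(CCCC#N)c2=O)cc1`) differs from compound 3 in one place: 2-cyanoethyl in place of cyano on a saturated chain carbon bound to an aromatic nitrogen. This puts 2-cyanoethyl in place of cyano on a saturated chain carbon bound to an aromatic nitrogen, turning cyanomethyl into 3-cyanopropyl.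

Going by the values given here, three measured steps bear on this change. They are no change at the digits printed from compound 1 to compound 3 (within the scatter), no change at the digits printed from compound 2 to compound 3 (within the scatter) and no change at the digits printed from compound 1 to compound 2 (within the scatter), and none of them moved the read-out beyond the scatter. None of them lengthens the chain that carries the nitrile, however, so the evidence is indirect. On these flat steps, no shift beyond the scatter is expected in either direction, and the expected change is no change at the digits printed from compound 3 to compound 4 (within the scatter). Compound 4 is estimated at 10000 nM, with an expected range of 4000 nM to 20000 nM.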

Compound 4, half-maximal inhibitory concentration: 10000 nM
Compound 4: middle estimate and measured number agree at the digits printed, within the range that was stated.
By their numbers in this assay, from the lowest: compounds 1, 2, 3 and 4 (each within the scatter of the next).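

Lengthening the chain that carries the nitrile, from cyanomethyl to 3-cyanopropyl, gives no change at the digits printed from compound 3 to compound 4 (within the scatter) in this assay, the first direct reading on chain length at this position. Set against the other two side chains on this saturated chain carbon bound to an aromatic nitrogen, ethoxycarbonyl and diethylcarbamoyl, the picture stays the same, with no change at the digits printed from compound 1 to compound 4 (within the scatter) and no change at the digits printed from compound 2 to compound 4 (within the scatter) for the change to 2-cyanoethyl. No measurement shown offers an explanation for this flat result.

The compounds shown leave open whether a different group at this place, such as a primary amine, a carboxylic acid or a longer chain carrying the nitrile, would move the read-out. They also leave open whether hydroxyl in place of a methoxy group on the shared core would do so.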